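A larger amino substituent on a potent styryl sulfone

A few compounds are considered here, and "the series" means these few. Any claim that something is new, unique, unknown or untested is made for them only; others in the source may bear on it.

Measured compounds:
- compound 1 `COc1ccc(CS(=O)(=O)/C=C/c2ccccc2OC)cc1N`: 7500 nM
- compound 2 `COc1cc(OC)c(/C=C/S(=O)(=O)Cc2ccc(F)c([N+](=O)[O-])c2)c(OC)c1`: 25000 nM
- compound 3 `COC(=O)CNc1cc(CS(=O)(=O)/C=C/c2c(OC)cc(OC)cc2OC)ccc1OC`: 100 nM

All three were tested in a functional assay on DU-145 cells (Homo sapiens) for cytotoxicity, read by trypan blue exclusion, with a stated time of 96 h; on this read-out higher numbers stand for weaker inhibition and lower numbers for stronger inhibition. Compound 3 gives the lowest number of the three, and its distance from both compound 1 and compound 2 lies beyond the usual scatter, so compound 3 is the strongest inhibitor in this small set. Compound 1 and compound 2 share the sulfone-linked styryl framework but differ from compound 3 in the groups on both aromatic rings, so no single change can be read from them.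

Compound 4 `COc1cc(OC)c(/C=C/S(=O)(=O)Cc2ccc(OC)c(NC(C(=O)O)c3ccc(Br)cc3)c2)c(OC)c1` keeps the core of compound 3 and differs only at the nitrogen on the aromatic ring: (4-bromophenyl)(carboxy)methyl in place of (methoxycarbonyl)methyl on a nitrogen on an aromatic ring. Going by the values given here, no measured pair shows this change, so its effect is unknown. A moderate move toward weaker inhibition is expected, a 4.0-fold higher number from compound 3 to compound 4 (0.60 log units; beyond the scatter), with wide uncertainty. Compound 4 is therefore estimated at 400 nM, within 100 nM to 2500 nM.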

Compound 4, half-maximal inhibitory concentration: 300 nM
Beside the measured number, compound 4's estimate is 1.3-fold (0.12 log units) above it, within the range that was stated.
By their numbers in this assay, from the lowest: compound 3; then compound 4; then compound 1; then compound 2.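

Replacing (methoxycarbonyl)methyl with (4-bromophenyl)(carboxy)methyl on a nitrogen on an aromatic ring gives, in this assay, a 3.0-fold higher number from compound 3 to compound 4 (0.48 log units; beyond the scatter), a modest step that lies beyond the scatter. This position therefore accepts a much larger group that brings in an aromatic ring, at only a modest cost in inhibition. Nothing available explains why the number rises.

The change swaps the methyl ester for a carboxy group and adds the 4-bromophenyl ring in one step, so the two contributions cannot be separated. A simple (carboxy)methyl group on this nitrogen would isolate the effect of the carboxy group, and a (phenyl)(carboxy)methyl group would show what the bromine contributes.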